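The source may hold more compounds than are shown below. What is called first, only, known or untested is meant among the compounds shown, and "the series" means these compounds.

In a functional assay on MCF7 cells (Homo sapiens) for antiproliferative activity, read by MTT assay, with a stated time of 48 h (on this read-out higher numbers stand for weaker inhibition and lower numbers for stronger inhibition), three compounds have been measured so far. Compound 1 `COc1ccc(OC(=O)C#Cc2ccccc2)cc1` gives 52600 nM, compound 2 `O=C1C=CC2(C=C1)OC(=O)C(c1ccc(CO)cc1)=C2c1ccccc1` gives 5760 nM, and compound 3 `COc1c(Br)cc(C)cc1C1=C(c2ccccc2)C2(C=CC(=O)C=C2)OC1=O` gives 5850 nM. Compound 2 has the lowest of these three numbers, but its gap to compound 3 lies within the scatter of repeated measurements, so the two cannot be told apart on this assay; only compound 1 stands clearly apart, with a markedly higher number than compound 2.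

Compound 4 `O=C1C=CC2(C=C1)OC(=O)C=C2c1ccccc1` has not yet been measured in this assay. It differs from compound 2 in one place: hydrogen in place of 4-(hydroxymethyl)phenyl on a double-bonded ring carbon. Going by the values given here, whether trimming back the shared core of compound 2 in this way matters is not told by any measured pair, since no two measured compounds differ by this single change. The expectation here is a moderate rise in the number for compound 4, that is, somewhat weaker inhibition than compound 2, with a step of about a 2.6-fold higher number from compound 2 to compound 4 (0.42 log units; beyond the scatter). Compound 4 is therefore estimated at 15000 nM, in a range from 5000 nM to 50000 nM.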

Compound 4, half-maximal inhibitory concentration: 6460 nM
For compound 4 the middle estimate is 2.3-fold (0.37 log units) above the measured one; the measured number falls inside the stated range.
By their numbers in this assay, from the lowest: compounds 2, 3 and 4 (each within the scatter of the next); then compound 1.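

In this assay, putting hydrogen in place of 4-(hydroxymethyl)phenyl on the double-bonded ring carbon comes with a 1.1-fold higher number from compound 2 to compound 4 (0.05 log units; within the scatter), so the two compounds cannot be told apart. This is the first pair shown that differs in one place, and it shows that the read-out holds without this whole group, aromatic ring and hydroxymethyl included. Nothing shown explains why the group can be lost at this position without a measurable difference.

On these data alone, this pair covers only hydrogen and 4-(hydroxymethyl)phenyl on this carbon, so it remains open how an amine, a carboxylic acid or a longer alkyl chain there would compare. Also open is whether the phenyl group on the nearby ring atom can be replaced in the same way, since no pair shown changes it alone.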